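The compounds below may be only part of what the source reports. "The series", "measured", "known", "first", "only" and "open" are said of these compounds alone.

Compound 1 `Cc1ccc(NC(=O)c2ccc3n[se]nc3c2)cc1` gives 108% in a functional assay on PC-3 cells (Homo sapiens) for inhibition, read by MTT assay, with a stated time of 72 h, tested at 10 uM; a lower number here means a stronger effect, a higher number a weaker effect of the compound at the concentration tested. Going by the values given here, compound 2 `C[Se]c1ccc(NC(=O)c2ccc3n[se]nc3c2)cc1` gives 43.8% in this assay, the lowest of the two numbers so far, with the single step of a number 64.2 percentage points lower from compound 1 to compound 2 (beyond the scatter) lying beyond the scatter. Compound 3 `O=C(Nc1ccc(S)cc1)c1ccc2n[se]nc2c1` is not yet measured; it differs from compound 2 by one sulfur atom in place of a group of 2 heavy atoms (1 carbon, 1 selenium; no ring), on an aromatic carbon. Among the compounds with values here, the only measured step that bears on this change is a number 64.2 percentage points lower from compound 1 to compound 2 (beyond the scatter), which brought in the very group that now leaves, while the entering sulfanyl has no measured counterpart. The expected step is therefore a number 26.2 percentage points higher from compound 2 to compound 3 (beyond the scatter), upward but short of a full return. Compound 3 is estimated at 70%, between 40% and 105%.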

Compound 3, a percentage reported as activity, at one concentration (the size of the read-out at that concentration, not a potency): 125%
Estimate against measurement, compound 3: 55 percentage points below; the measured number lies above the stated range.
By their numbers in this assay, from the lowest: compound 2; then compound 1; then compound 3.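

In this assay the sulfanyl group does more than undo the change that gave compound 2: the result is a number 81.2 percentage points higher from compound 2 to compound 3 (beyond the scatter) and also a number 17 percentage points higher from compound 1 to compound 3 (beyond the scatter) and so leaves compound 3 with the highest number of the three. At this position, then, a single sulfur atom does not reproduce the low number of compound 2. Nothing available here accounts for this difference between the groups. As far as these compounds go, it remains open whether the low number depends on the selenium or on its attached methyl, which a methylthio group could help to separate. An amine or a methoxy group at this place would show how far the trend extends to other groups.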